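From 3,5-dimethoxyphenyl to phenyl on an amide-type nitrogen

This account rests on a few compounds, and the source may have more. Where it says the series, first, only, none or still open, it means among the compounds named here.

Measured so far in a functional assay on RPMI-8226 cells (Homo sapiens) for antiproliferative activity, read by MTT assay, with a stated time of 72 h; on this read-out lower numbers stand for stronger inhibition and higher numbers for weaker inhibition:
- compound 1 `CCc1cccc(NC(=O)C(=O)[C@H](CC(C)C)NC(=O)[C@H](CC(C)C)NC(=O)[C@H](CC(C)C)NC(=O)OCc2ccccc2)c1` gives 40.4 nM
- compound 2 `COc1cc(NC(=O)C(=O)[C@H](CC(C)C)NC(=O)[C@H](CC(C)C)NC(=O)[C@H](CC(C)C)NC(=O)OCc2ccccc2)cc(OC)c1` gives 37.6 nM

Compound 2 stands level with compound 1, as their two values lie within the scatter of each other and neither ranks ahead. The next compound to be read is compound 3 `CC(C)C[C@H](NC(=O)OCc1ccccc1)C(=O)N[C@@H](CC(C)C)C(=O)N[C@@H](CC(C)C)C(=O)C(=O)Nc1ccccc1`. It differs from compound 2 as follows: phenyl in place of 3,5-dimethoxyphenyl on an amide-type nitrogen. In words, this is phenyl in place of 3,5-dimethoxyphenyl on an amide-type nitrogen.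

Going by the values given here, only one measured step bears on this place, and it stayed within the scatter: a 1.1-fold lower number from compound 1 to compound 2 (0.03 log units; within the scatter). That step put 3,5-dimethoxyphenyl in place of 3-ethylphenyl. Among the compounds with values here, it is a single comparison, and no measured compound yet carries phenyl here, so the evidence is thin. No step beyond the scatter is therefore expected in this assay, in either direction, though the margin must stay wide. The expected change is a 1.1-fold higher number from compound 2 to compound 3 (0.03 log units; within the scatter) as estimated. Compound 3 is estimated at 40 nM, with an expected range from 15 nM to 110 nM.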

Compound 3, half-maximal inhibitory concentration: 67.8 nM
Compound 3: the middle estimate sits 1.7-fold (0.23 log units) below what was measured, within the range that was stated.
By their numbers in this assay, from the lowest: compounds 2, 1 and 3 (each within the scatter of the next).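

In this assay, phenyl in place of 3,5-dimethoxyphenyl on the amide-type nitrogen gives a 1.8-fold higher number from compound 2 to compound 3 (0.26 log units; within the scatter) and hydrogen in place of ethyl on an aromatic carbon gives a 1.7-fold higher number from compound 1 to compound 3 (0.22 log units; within the scatter) as the second comparison at this place. The earlier pair only set one substituted ring against another, whereas compound 3 adds a ring with no substituent, and it still cannot be told apart from compound 1 or compound 2, so neither the ethyl nor the two methoxy groups separate these three compounds on this read-out. Nothing accompanies these values that could account for the size of either step.

What the three compounds leave open is whether any group at this place can move the number beyond the scatter, since all of them carry a six-membered aromatic ring of carbon only on this nitrogen. A pyridine ring, a phenyl bearing a carboxylic acid or an amine, or a saturated chain such as butyl on the same nitrogen would test how far this tolerance extends.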